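This account rests on a few compounds, and the source may have more. Where it says the series, first, only, none or still open, it means among the compounds named here.

Measured in a physicochemical assay for metabolic stability, read by LC-MS, in simulated gastric fluid, with a stated time of 15 min, tested at 50 uM; a higher number here means that more of the compound is left, a lower number that less of the compound is left:
compound 1 `COc1ccc(CNC(=O)c2c(C)nc3cc(C)ccn23)cc1`: 100%
compound 2 `CCC(=O)c1ccccc1OC(=O)c1coc(-c2ccccc2)n1`: 1.8%
compound 3 `Cc1cc(C)c(OC(=O)c2coc(-c3ccccc3)n2)c(C)c1`: 1.4%

Compound 2 lies within the scatter of compound 3 and far under compound 1, so very little of it is left. Compound 4 `CCCc1ccccc1OC(=O)c1coc(-c2ccccc2)n1` differs from compound 2 in one place: propyl in place of propanoyl on an aromatic carbon. The carbonyl of the propanoyl is gone and the rest of the molecule stays the same. Going by the values given here, no measured pair shows this change directly. Compound 3 also carries no propanoyl and still gives 1.4%. On that basis, the estimated step of a number 1.2 percentage points higher from compound 2 to compound 4 (within the scatter) in this assay is expected to stay within the scatter. For compound 4 the expected value is 3%, with an estimated range of 0.5% to 15%.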

Compound 4, percent of the compound remaining: 0.9%
Beside the measured number, compound 4's estimate is 2.1 percentage points above it; the range from low to high includes it.
By their numbers in this assay, from the lowest: compounds 4, 3 and 2 (each within the scatter of the next); then compound 1.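

In this assay, putting propyl in place of propanoyl on the aromatic carbon gives a number 0.9 percentage points lower from compound 2 to compound 4 (within the scatter) and so makes no clear difference. Going by these compounds alone, this is the first direct comparison at this position, and it shows that the low number of compound 2 does not depend on the carbonyl of its propanoyl. No available evidence explains this result.

From the compounds shown here alone, whether an amine or a carboxylic acid at this position would leave more of the compound is still open. So is whether any group placed here can move the number at all.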